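Aryl swap on the sulfonyl of a pyrrolidine sulfonamide

The compounds below may be only part of what the source reports. "The series", "measured", "known", "first", "only" and "open" are said of these compounds alone.

The study concerns compounds sharing the core of compound 1 `COC[C@@H]1CC[C@H](c2ccc(F)cc2)N1S(=O)(=O)c1cc(C)c(F)c(C)c1`, which in an assay on isolated protein for inhibition of transient receptor potential cation channel subfamily A member 1 (Homo sapiens) (on this read-out higher numbers stand for weaker inhibition and lower numbers for stronger inhibition), gives 270 nM. Compound 2 `Cc1cc(S(=O)(=O)N2[C@H](CN(C)C)CC[C@@H]2c2ccc(F)cc2)cc(C)c1F` differs by a dimethylamino in place of methoxy on a saturated chain carbon, and in this assay compound 2 sits at a limit of > 18000 nM. Among the measured compounds shown here, the step of an at least 66-fold higher number from compound 1 to compound 2 (1.82 log units; beyond the scatter) is the only measured step with a single change, and it concerns the chain, not the sulfonyl aryl.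

Compound 3 `O=S(=O)(c1ccc(F)cn1)N1[C@H](CO)CC[C@@H]1c1ccc(F)cc1` carries a hydroxymethyl chain and a 5-fluoropyridin-2-yl on the sulfonyl; in this assay compound 3 reports only a limit of > 20000 nM, so its position among the three is known only as a limit (the limit of > 20000 nM in this assay, at which 1 of the 3 values shown sits).

Compound 4 `Cc1cc(S(=O)(=O)N2[C@H](CO)CC[C@@H]2c2ccc(F)cc2)ccc1F` differs from compound 3 by 4-fluoro-3-methylphenyl in place of 5-fluoropyridin-2-yl on a sulfonyl sulfur. For the measured compounds named here, no measured step covers this aryl change, so the expectation rests loosely on compound 1 with its 270 nM and a related aryl. A step of an at least 6.6-fold lower number from compound 3 to compound 4 (0.82 log units; beyond the scatter) toward stronger inhibition is expected, though uncertain. Compound 4 is estimated at 3000 nM, between 400 nM and 20000 nM.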

Compound 4, half-maximal inhibitory concentration: 190 nM
Compound 4: middle estimate off by 16-fold (1.20 log units), on the high side; the measured number lies below the stated range.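

In this assay, with the hydroxymethyl chain held fixed, putting 4-fluoro-3-methylphenyl in place of 5-fluoropyridin-2-yl on the sulfonyl sulfur gives an at least 100-fold lower number from compound 3 to compound 4 (2.02 log units; beyond the scatter). Among the compounds shown here, the earlier compounds showed a large step only at the chain, so this is the first sign that the aryl on the sulfonyl sulfur can also carry a large step. For compound 3 the value is a limit and not a number, so the size of the step is a limit as well: the limit of > 20000 nM in this assay, at which 1 of the 4 values shown sits.

The swap removes the ring nitrogen and adds the methyl together, so the compounds shown do not tell which of the two carries the step. On these data alone, a 4-fluorophenyl on the sulfonyl sulfur would separate them, and how a pyridine ring bearing a methyl would read remains open too.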